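This account rests on a few compounds, and the source may have more. Where it says the series, first, only, none or still open, it means among the compounds named here.

Compound 1, with the structure `O=C(NCc1ccco1)c1ccc(CN2C(=O)c3ccccc3S2(=O)=O)cc1`, is tested in an ADME assay on RAW264.7 cells (Mus musculus) for cytotoxicity, read by WST assay; a higher number here means that more compound is tolerated, a lower number that less compound is tolerated. In this assay compound 1 gives > 100000 nM, which is a limit of the assay rather than a number. A related compound 2 `O=C(NCc1ccco1)c1ccc(CN2Cc3ccccc3C2=O)cc1` is tested as well; in this assay compound 2 gives > 100000 nM, again a limit. Compound 3 `CC(C)(C)OC(=O)N(Cc1ccco1)C(=O)c1ccc(Cn2sc3ccccc3c2=O)cc1` in this assay gives > 100000 nM, also a limit. Compound 1 therefore stands where every measured compound stands, namely at the limit of > 100000 nM in this assay, at which 3 of the 3 values shown sit. Compound 4 `CNC(=O)c1ccc(CN2C(=O)c3ccccc3S2(=O)=O)cc1` has not yet been measured. It differs from compound 1 by hydrogen in place of furan-2-yl on a saturated chain carbon bound to an amide-type nitrogen. Since every measured value sits at the limit of > 100000 nM in this assay, at which 3 of the 3 values shown sit, no step beyond the usual scatter is expected in either direction. For compound 4 in this assay the estimate is 150000 nM, within 50000 nM to 500000 nM. This corresponds to an expected step that the limit leaves unreadable from compound 1 to compound 4.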

Compound 4, concentration lethal to 50% of the cells: > 100000 nM
Compound 4 gave a limit, no number; the forecaster's own chance of this, stated with the estimate: 85%; the middle value is on the limit's open side.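

Compound 1 and compound 4 each give only a limit in this assay, and no step can be read between them. The compounds shown leave open at what concentration any of them would become lethal to the cells.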